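The source may hold more compounds than are shown below. What is called first, only, known or untested is meant among the compounds shown, and "the series" means these compounds.

- Compound 1 `Fc1cccc(-c2nc(Nc3ccc(Br)cc3)c3cc(F)ccc3n2)c1`: > 50000 nM (a limit of the assay)
- Compound 2 `Oc1ccccc1Nc1nc(-c2cccc(F)c2)nc2ccc(F)cc12`: 44400 nM

Both compounds were tested in a functional assay on HL-60 cells (Homo sapiens) for cytotoxicity, read by MTT assay, with a stated time of 48 h; on this read-out lower numbers stand for stronger inhibition and higher numbers for weaker inhibition. Compound 1 gives > 50000 nM, which is a limit and not a measured number. Going by the values given here, compound 2, at 44400 nM, holds the only actual number in this small set, so it has no measured neighbour to be ranked against. The evidence so far is therefore thin, and it includes (the limit of > 50000 nM in this assay, at which 1 of the 2 values shown sits).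

Compound 3 `Nc1ccc(Nc2nc(-c3cccc(F)c3)nc3ccc(F)cc23)cc1` keeps the core of compound 2 but carries 4-aminophenyl in place of 2-hydroxyphenyl on a nitrogen on an aromatic ring. Among the compounds with values here, the same nitrogen carries the group that changed in the one measured step, an at least 1.1-fold lower number from compound 1 to compound 2 (0.05 log units; that floor lies within the scatter). The floor of that step lies within the scatter, so no shift beyond the scatter is expected in this assay. The expected change is a 1.5-fold lower number from compound 2 to compound 3 (0.17 log units; within the scatter). For compound 3 the estimated value is 30000 nM, with an expected range from 8000 nM to 60000 nM.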

Compound 3, half-maximal inhibitory concentration: > 50000 nM
Compound 3: only a limit was reported; the forecaster's own chance of this, stated with the estimate: 30%; middle value at least 1.6-fold (0.22 log units) away from the limit.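

In this assay, putting 4-aminophenyl in place of 2-hydroxyphenyl on the same nitrogen gives an at least 1.1-fold higher number from compound 2 to compound 3 (0.05 log units; that floor lies within the scatter), so a second kind of substituted phenyl at this position also shows no shift beyond the scatter, although the true size of this step is hidden behind a limit. Compound 3 gives > 50000 nM, which is a limit of the assay and not a number. Going by these compounds alone, the step between compound 1 and compound 3 cannot be read, so compound 2 still holds the only actual number, and a third group on this nitrogen has added one more compound to the limit: the limit of > 50000 nM in this assay, at which 2 of the 3 values shown sit.

As far as these compounds go, it remains open whether any other group on this nitrogen, such as a plain phenyl, a methoxyphenyl, a phenyl carrying a carboxylic acid or a simple alkyl chain, would give a number well clear of that limit. A plain phenyl would also help to show whether the hydroxyl group of the 2-hydroxyphenyl has any part in the number of compound 2.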